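Swapping a carboxy for a methyl on the aryl imine

A few compounds are considered here, and "the series" means these few. Any claim that something is new, unique, unknown or untested is made for them only; others in the source may bear on it.

The measured compounds, read in a functional assay on MCF7 cells (Homo sapiens) for cytotoxicity, read by sulforhodamine B assay, with a stated time of 24 h; on this read-out lower numbers stand for stronger inhibition and higher numbers for weaker inhibition:

Compound 1, `O=C1Nc2ccc(S(=O)(=O)N3CCOCC3)cc2/C1=N/NC(=O)c1ccccc1`, gives 414000 nM.
Compound 2, `O=C1Nc2ccc(S(=O)(=O)N3CCOCC3)cc2/C1=N/c1cccc(C(F)(F)F)c1`, gives 41100 nM.
Compound 3, `O=C1Nc2ccc(S(=O)(=O)N3CCOCC3)cc2/C1=N/c1ccc(C(=O)O)cc1`, gives 26700 nM.

Compound 3 has the smallest number of the three. Its distance from compound 1 is a 16-fold lower number from compound 1 to compound 3 (1.19 log units; beyond the scatter), whereas its distance from compound 2 is only a 1.5-fold lower number from compound 2 to compound 3 (0.19 log units; within the scatter), so compound 2 and compound 3 cannot be told apart.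

Compound 4, `Cc1ccc(/N=C2\C(=O)Nc3ccc(S(=O)(=O)N4CCOCC4)cc32)cc1`, is compound 3 with one change: methyl in place of carboxy on an aromatic carbon. Within the data shown here, no measured step exchanges these two groups. The steps of a 10-fold lower number from compound 1 to compound 2 (1.00 log units; beyond the scatter) and a 16-fold lower number from compound 1 to compound 3 (1.19 log units; beyond the scatter) both replace the benzamido group with an aryl ring and are large, but they concern a different part of the molecule. Among the measured compounds shown here, the only step that alters the group on the aryl ring, a 1.5-fold lower number from compound 2 to compound 3 (0.19 log units; within the scatter), stays within the scatter. The exchange of a carboxy for a methyl on that ring is therefore expected to produce no step beyond the scatter in this assay, in either direction.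

Compound 4 is thus estimated at 30000 nM, with a range from 10000 nM to 90000 nM, which corresponds to an expected step of a 1.1-fold higher number from compound 3 to compound 4 (0.05 log units; within the scatter).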

Compound 4, half-maximal inhibitory concentration: 55900 nM
Estimate against measurement, compound 4: 1.9-fold (0.27 log units) below; measured number inside the range.
By their numbers in this assay, from the lowest: compounds 3, 2 and 4 (each within the scatter of the next, the first and the last beyond it); then compound 1.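

Read in this assay, putting methyl in place of carboxy on the aromatic ring gives the first direct comparison of these two groups (a 2.1-fold higher number from compound 3 to compound 4 (0.32 log units; beyond the scatter)), a modest step showing that a change at this place can carry the number past the scatter, which the earlier exchange of aryl groups did not do. Among these compounds, the new compound still cannot be told apart from the one bearing 3-(trifluoromethyl)phenyl (a 1.4-fold higher number from compound 2 to compound 4 (0.13 log units; within the scatter)), and it stays well clear of the benzamido compound (a 7.4-fold lower number from compound 1 to compound 4 (0.87 log units; beyond the scatter)), so 4-methylphenyl joins the other two aryl groups in giving lower numbers than benzamido, with no compound among the four going against this. Nothing available on these compounds accounts for the difference between carboxy and methyl, and the size of the step alone offers no explanation.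

As far as these compounds go, with only carboxy and methyl compared at this place, it remains open how an amine, a methoxy group or a longer alkyl chain on the same aromatic carbon would read. From the compounds shown here alone, it also remains open whether the same order would hold on other cell types or after a different exposure time, and whether any of these aryl groups would reach far lower numbers on the shared core.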